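Thiosemicarbazide series: cyclic amine swap on thiocarbonyl

The compounds below may be only part of what the source reports. "The series", "measured", "known", "first", "only" and "open" are said of these compounds alone.

Measured compounds:
- compound 1 `Cc1cccc(/C(N)=N/NC(=S)N2CCSCC2)n1`: 22.5%
- compound 2 `N/C(=N\NC(=S)N1CCCCC1)c1ccccn1`: 53.1%
- compound 3 `Cc1cccc(/C(N)=N/NC(=S)N2CCOCC2)n1`: 39.1%

In a functional assay on MCF7 cells (Homo sapiens) for cytotoxicity, read by MTT assay, with a stated time of 72 h, tested at 10 uM (a higher number here means more inhibition of growth at the concentration tested, a lower number less inhibition of growth), compound 3 stands second highest of the three numbers. Going by the values given here, compound 1 sits below it, and the step of a number 16.6 percentage points higher from compound 1 to compound 3 (beyond the scatter) is the only single-place change measured so far. Among the compounds with values here, compound 2 sits above compound 3, but compound 2 and compound 3 differ in two places, so no single step links them; their values can only be set side by side.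

Compound 4 `Cc1cccc(/C(N)=N/NC(=S)N2CCCCC2)n1` is not yet measured. It differs from compound 3 by piperidin-1-yl in place of morpholin-4-yl on a thiocarbonyl carbon. Within the data shown here, no measured step covers this exact exchange. Among the measured compounds shown here, the one step that bears on a change of the cyclic amine on the thiocarbonyl carbon, a number 16.6 percentage points higher from compound 1 to compound 3 (beyond the scatter), was modest. For the measured compounds named here, compound 2, the only measured compound carrying piperidin-1-yl, gives 53.1%, the highest number of the three. A modest upward step is therefore expected, with wide uncertainty.

For compound 4 the estimate in this assay is 46%, within 28% to 64%, which means an expected step of a number 6.9 percentage points higher from compound 3 to compound 4 (within the scatter).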

Compound 4, percent growth inhibition at one concentration: 39%
The estimate for compound 4 lay 7 percentage points above the measured number; the range from low to high includes it.
By their numbers in this assay, from the lowest: compound 1; then compounds 4 and 3 (each within the scatter of the next); then compound 2.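

In this assay, on a thiocarbonyl carbon with the rest of the structure held constant, piperidin-1-yl and morpholin-4-yl are not told apart: a number 0.1 percentage points lower from compound 3 to compound 4 (within the scatter). Thiomorpholin-4-yl is the group that separates here, since piperidin-1-yl gives a number 16.5 percentage points higher from compound 1 to compound 4 (beyond the scatter), of similar size to the earlier a number 16.6 percentage points higher from compound 1 to compound 3 (beyond the scatter). The methyl on an aromatic carbon now has its first single-place reading, a number 14.1 percentage points lower from compound 2 to compound 4 (beyond the scatter), so the high number of compound 2 goes with hydrogen at that carbon and not with piperidin-1-yl alone.

No measurement given here accounts for these differences. Open, on these data alone, are whether a piperazine or an open-chain dimethylamino group on the thiocarbonyl carbon would fall with compound 1 or with compound 3 and compound 4, and whether the methyl step holds with other cyclic amines.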